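Configuration at the chain stereocentre in benzylamide series

The compounds below may be only part of what the source reports. "The series", "measured", "known", "first", "only" and "open" are said of these compounds alone.

Measured compounds:
compound 1 `CCC[C@@H](N)C(=O)NCc1ccccc1`: 21 mg/kg
compound 2 `N[C@@H](C(=O)NCc1ccccc1)C1CCCCC1`: 28 mg/kg
compound 3 `CSCC[C@@H](N)C(=O)NCc1ccccc1`: 75 mg/kg

In a functional assay on the whole organism (strain NMRI) with Mus musculus as the target, in the maximal electroshock model, with a stated time of 30 min (a higher number here means that more compound is needed for the effect, a lower number that less compound is needed), compound 1 gives the lowest of the three numbers; compound 2 lies within the scatter of it (a 1.3-fold higher number from compound 1 to compound 2 (0.12 log units; within the scatter)), while compound 3 is further off (a 3.6-fold higher number from compound 1 to compound 3 (0.55 log units; beyond the scatter)). Compound 4 `CCC[C@H](N)C(=O)NCc1ccccc1` differs from compound 1 only as follows: the two compounds have the same atoms and bonds and differ only in configuration as drawn: 1 of 1 stereo elements differ; a stereocentre at a saturated chain carbon is drawn R in compound 1 and S in compound 4. For the measured compounds named here, every measured step changes the side chain; none changes configuration alone, so no measured step bears directly on this one. The step of a 1.7-fold higher number from compound 1 to compound 4 (0.22 log units; within the scatter) is therefore an expectation without a close precedent, and the range around it is kept wide. Compound 4 is estimated at 35 mg/kg, with a likely span from 12 mg/kg to 110 mg/kg.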

Compound 4, dose for half-maximal effect: > 37 mg/kg
Compound 4: only a limit was reported (the forecaster's own chance of this, stated with the estimate: 10%); middle value at least 1.0-fold (0.02 log units) from the limit.
By their numbers in this assay, from the lowest: compounds 1 and 2 (each within the scatter of the next); then compound 3.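

In this assay compound 4 gives > 37 mg/kg, which is a limit and not a number. For the compounds shown here, this is the first reading on configuration alone at this chain stereocentre, with the propyl side chain held constant, and the result is an at least 1.7-fold higher number from compound 1 to compound 4 (0.24 log units; that floor lies within the scatter). Any gap in this pair can therefore be tied to configuration alone, though its size remains unresolved: the fact that compounds 1 and 4 differ only in the configuration as drawn

On these data alone, the true value of compound 4 remains open. So does the effect of the same inversion with a phenyl group or a longer chain in place of propyl.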